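Aryl swap at the ketone carbonyl: outlook for compound 4

The source may report more compounds than this note shows. Statements on the series, on what has been measured and on what is new or still open speak of the compounds shown alone.

Measured so far:
compound 1 `COc1ccc(C(=O)c2cc(C)ccc2OCC(=O)NNC(=O)c2cc3ccccc3oc2=O)cc1` — compound 1 gives 41200 nM in a functional assay on Ehrlich cells (Mus musculus) for cytotoxicity, read by trypan blue exclusion, with a stated time of 48 h; on this read-out lower numbers stand for stronger inhibition and higher numbers for weaker inhibition
compound 2 `Cc1ccc(OCC(=O)NNC(=O)c2cc3ccccc3oc2=O)c(C(=O)c2ccccc2Cl)c1` — compound 2 gives 48400 nM in this assay
compound 3 `Cc1ccc(OCC(=O)NNC(=O)c2cc3ccccc3oc2=O)c(C(=O)c2ccc(F)cc2)c1` — compound 3 gives 43400 nM in this assay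

Compound 2 carries the highest of the three numbers, but it is not separated from the others: the step of a 1.2-fold higher number from compound 1 to compound 2 (0.07 log units; within the scatter) and the step of a 1.1-fold lower number from compound 2 to compound 3 (0.05 log units; within the scatter) both lie within the scatter, as does a 1.1-fold higher number from compound 1 to compound 3 (0.02 log units; within the scatter). Across the three measured aryl groups on the carbonyl carbon, then, the read-out has not moved beyond noise.

Compound 4 `Cc1ccc(C(=O)c2cc(C)ccc2OCC(=O)NNC(=O)c2cc3ccccc3oc2=O)cc1` is the next variation at the same place. It differs from compound 2 by 4-methylphenyl in place of 2-chlorophenyl on a carbonyl carbon.

The bearing steps are the two that already exchange the aryl group on the carbonyl carbon, a 1.2-fold higher number from compound 1 to compound 2 (0.07 log units; within the scatter) and a 1.1-fold lower number from compound 2 to compound 3 (0.05 log units; within the scatter), each within the scatter. Among the compounds with values here, nothing among the measured compounds points to a change beyond the scatter for a further aryl exchange at this carbon, so no directional step in this assay is expected; the estimate is a step of a 1.1-fold lower number from compound 2 to compound 4 (0.03 log units; within the scatter), essentially flat. Compound 4 is therefore expected to give 45000 nM, with a range from 25000 nM to 85000 nM.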

Compound 4, half-maximal inhibitory concentration: 82600 nM
For compound 4 the middle estimate is 1.8-fold (0.26 log units) below the measured one, and the stated range covers the measured number.
By their numbers in this assay, from the lowest: compounds 1, 3, 2 and 4 (each within the scatter of the next).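

In this assay the exchange of 2-chlorophenyl for 4-methylphenyl on the carbonyl carbon amounts to a 1.7-fold higher number from compound 2 to compound 4 (0.23 log units; within the scatter) and so, like the earlier exchanges at this place, stays within the scatter, although it is a wider step than any among compound 1, compound 2 and compound 3. With the aryl group otherwise alike, methyl in place of fluoro amounts to a 1.9-fold higher number from compound 3 to compound 4 (0.28 log units; within the scatter) and methyl in place of methoxy amounts to a 2.0-fold higher number from compound 1 to compound 4 (0.30 log units; within the scatter) and these two are also wider steps that remain within the scatter, so the four aryl groups on this carbon show no separation that can be read. No measured evidence is available to account for the size of these steps.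

On these data alone, whether an amine, a carboxylic acid or a longer alkyl chain on this aryl group would take the read-out beyond the scatter remains open. Also open, as far as these compounds go, is what a cyclohexyl or pyridine ring in place of the aryl group on the carbonyl carbon would do, as is the outcome of any change elsewhere in the shared core.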